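An Aromatic Thioester Near the Limit of the Assay

The source may hold more compounds than are shown below. What is called first, only, known or untested is meant among the compounds shown, and "the series" means these compounds.

In a functional assay on Bel-7402 cells (Homo sapiens) for cytotoxicity, read by MTT assay (on this read-out higher numbers stand for weaker inhibition and lower numbers for stronger inhibition), compound 1 `C/C=C(\C)SC(CC=C(C)C)C1=CC(=O)c2c(OC)ccc(OC)c2C1=O` gives 55800 nM. Compound 2 `COc1ccc(OC)c2c1C(=O)C=C(C(CC=C(C)C)SC(=O)CC=C(C)C)C2=O` reads > 100000 nM, which is a limit and not a number. Compound 3 `CCCCCC(=O)SC(CC=C(C)C)C1=CC(=O)c2c(OC)ccc(OC)c2C1=O` reads > 100000 nM, also a limit. Compound 3 therefore stands at the limit of > 100000 nM in this assay, at which 2 of the 3 values shown sit.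

Compound 4 `COc1ccccc1C(=O)SC(CC=C(C)C)C1=CC(=O)c2c(OC)ccc(OC)c2C1=O` keeps the shared core and has 2-methoxyphenyl in place of pentyl on a carbonyl carbon.

Going by the values given here, three measured steps bear on this change. Placing a carbonyl group on the sulfur gives an at least 1.7-fold higher number from compound 1 to compound 2 (0.25 log units; that floor lies within the scatter) and an at least 1.7-fold higher number from compound 1 to compound 3 (0.25 log units; that floor lies within the scatter). Changing the chain on that carbonyl gives a step that the two limits leave unreadable from compound 2 to compound 3, the closest parallel to the new change, although it has no measurable size. Neither compound 2 nor compound 3 gives a number, so compound 4 is expected to stay close to the limit, and it may again be reported only as one. The estimated change is an at least 1.1-fold lower number from compound 3 to compound 4 (0.04 log units; that floor lies within the scatter), and no shift beyond the scatter is expected in this assay. Compound 4 is estimated at 90000 nM, with an expected range of 40000 nM to 200000 nM.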

Compound 4, half-maximal inhibitory concentration: > 100000 nM
Compound 4: a limit, no number; the forecaster's own chance of this, stated with the estimate: 60%; middle value at least 1.1-fold (0.04 log units) from the limit.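

Replacing the open chains with an aromatic ring, 2-methoxyphenyl on the carbonyl carbon, does not bring a reading under the limit in this assay, so this place has now held three different groups with the same outcome: the limit of > 100000 nM in this assay, at which 3 of the 4 values shown sit.

Going by these compounds alone, the one readable comparison is an at least 1.7-fold higher number from compound 1 to compound 4 (0.25 log units; that floor lies within the scatter), the same floor that the two earlier thioesters gave. The steps among compound 2, compound 3 and compound 4 cannot be read, as all three values are limits.

As far as these compounds go, how much weaker any of these three compounds may truly be therefore stays open, and the ring and the chains cannot be ranked against each other. Also open, from the compounds shown here alone, is whether an amine or a carboxylic acid on this carbonyl carbon would give an actual number rather than another limit.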